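Allyl for Ethyl Carried onto a Second Core

The compounds below may be only part of what the source reports. "The series", "measured", "known", "first", "only" and "open" are said of these compounds alone.

Compound 1 `C=CCNc1[nH]nc(N)c1C(=O)Nc1ccc(OCC)cc1` and compound 2 `CCNc1[nH]nc(N)c1C(=O)Nc1ccc(OCC)cc1` share one core, while compound 3 `CCNc1[nH]nc2nnn(-c3ccc(OCC)cc3)c(=O)c12` and the as yet unmeasured compound 4 `C=CCNc1[nH]nc2nnn(-c3ccc(OCC)cc3)c(=O)c12` share another; the difference between the two cores is not broken down here. In a functional assay on CCRF-CEM cells (Homo sapiens) for cytotoxicity, read by resazurin assay, with a stated time of 48 h (on this read-out higher numbers stand for weaker inhibition and lower numbers for stronger inhibition), compound 2 gives 14000 nM, compound 1 gives 6560 nM, and compound 3 gives 15200 nM. The values of compound 3 and compound 2 lie within the scatter of each other. The change from compound 2 to compound 1 is vinyl in place of methyl on a saturated chain carbon bound to a nitrogen on an aromatic ring and it produced a step of a 2.1-fold lower number from compound 2 to compound 1 (0.33 log units; beyond the scatter). Compound 4 carries the same change relative to compound 3, namely (vinyl in place of methyl on a saturated chain carbon bound to a nitrogen on an aromatic ring). Resting on that single measured instance, the step from compound 3 to compound 4 is expected to be a 2.0-fold lower number from compound 3 to compound 4 (0.31 log units; beyond the scatter). For compound 4 in this assay the estimate is 7500 nM, with a range from 3500 nM to 16000 nM.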

Compound 4, half-maximal inhibitory concentration: 4730 nM
For compound 4 the middle estimate is 1.6-fold (0.20 log units) above the measured one; the measured number falls inside the stated range.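

Replacing ethyl with allyl on the second core gave a 3.2-fold lower number from compound 3 to compound 4 (0.51 log units; beyond the scatter) in this assay, the same direction as on the first core, where the change gave a 2.1-fold lower number from compound 2 to compound 1 (0.33 log units; beyond the scatter). The two steps do not differ in size beyond what such steps scatter: the same change on two cores in this assay, a 2.1-fold lower number (0.33 log units; beyond the scatter) from compound 2 to compound 1 and a 3.2-fold lower number (0.51 log units; beyond the scatter) from compound 3 to compound 4, 1.5-fold (0.18 log units) apart, within the scatter of two such steps. This shows that the change carried from one core to the other in this assay, but two pairs do not show that it would carry to a further core, and they do not explain why the number falls.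

The compounds shown leave open whether a longer chain such as butyl, or a chain ending in an amine, would do the same in place of allyl. They also leave open whether the step holds in any other cell line.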